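Hydroxyl position shift in a HeLa inhibition series

A few compounds are considered here, and "the series" means these few. Any claim that something is new, unique, unknown or untested is made for them only; others in the source may bear on it.

Compound 1 `Oc1cccc(-c2cc(-c3cccc(F)c3)cc(-c3cccc(O)c3)n2)c1` anchors the series; in a functional assay on HeLa cells (Homo sapiens) for inhibition (a higher number here means a weaker inhibitor, a lower number a stronger inhibitor), compound 1 gives 1400 nM. Compound 2 `Oc1ccc(-c2cc(-c3cccc(F)c3)cc(-c3cccc(O)c3)n2)cc1` carries 4-hydroxyphenyl in place of 3-hydroxyphenyl on an aromatic carbon and in this assay compound 2 gives 14200 nM, so a 10-fold higher number from compound 1 to compound 2 (1.01 log units; beyond the scatter). Compound 3 `Oc1cccc(-c2cc(-c3ccccc3C(F)(F)F)cc(-c3ccccc3O)n2)c1` rests on a different core; in this assay compound 3 gives 16800 nM, a number close to that of compound 2 and well above that of compound 1. The difference between the core of compound 3 and that of compound 1 is not broken down here. Compound 4 `Oc1ccc(-c2cc(-c3ccccc3C(F)(F)F)cc(-c3ccccc3O)n2)cc1`, not yet measured, carries 4-hydroxyphenyl in place of 3-hydroxyphenyl on an aromatic carbon. This is the same kind of change as from compound 1 to compound 2, but the surroundings of the place differ: here it stands meta to a 2-(trifluoromethyl)phenyl group and meta to a 2-hydroxyphenyl group, there meta to a 3-fluorophenyl group and meta to a 3-hydroxyphenyl group. Going by the values given here, only one measured instance of the change exists, and its surroundings are not the same, so the expected step from compound 3 to compound 4 is set smaller than the measured one: a 3.6-fold higher number from compound 3 to compound 4 (0.55 log units; beyond the scatter) is expected. Compound 4 is estimated at 60000 nM in this assay, expected to fall between 15000 nM and 250000 nM.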

Compound 4, half-maximal inhibitory concentration: 16500 nM
For compound 4 the middle estimate is 3.6-fold (0.56 log units) above the measured one; the range from low to high includes it.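

In this assay, 4-hydroxyphenyl in place of 3-hydroxyphenyl gives a 1.0-fold lower number from compound 3 to compound 4 (0.01 log units; within the scatter), so on the core of compound 3 the change leaves no readable difference. The change therefore does not carry over as a fixed step between these two cores: the same change on two cores in this assay, a 10-fold higher number (1.01 log units; beyond the scatter) from compound 1 to compound 2 and a 1.0-fold lower number (0.01 log units; within the scatter) from compound 3 to compound 4, 10-fold (1.01 log units) apart, beyond the scatter of two such steps This shows that the size of the step depends on the surroundings in this small set, but with a single instance on each core it does not show which difference between the two cores is responsible, nor how the step would read on any third core.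

Open, on these data alone, is whether the gap between the two steps follows the 2-(trifluoromethyl)phenyl group or the 2-hydroxyphenyl group, which a core differing from that of compound 1 in only one of these places would separate. Also open, as far as these compounds go, is how an amine or a carboxylic acid in place of the hydroxyl of the moved ring would read in this assay.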